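The source may hold more compounds than are shown below. What is called first, only, known or untested is meant among the compounds shown, and "the series" means these compounds.

Working notes, thiophene-free wording, measured set in a functional assay on HCT-116 cells (Homo sapiens) for inhibition, read by MTT assay, with a stated time of 72 h, tested at 20 uM; on this read-out lower numbers stand for less inhibition and higher numbers for more inhibition at the one concentration tested (going by the name of the read-out):

compound 1 `CN(c1ccc(Oc2ncnc3sccc23)cc1)c1nccc(N2CCCC2)n1`: 42.2%
compound 2 `CN(c1ccc(Oc2ncnc3sccc23)cc1)c1nccc(N2CCCCC2)n1`: 52.2%
compound 3 `c1cc(N2CCCCC2)nc(Nc2ccc(Oc3ncnc4ccsc34)cc2)n1`: 61.5%

Compounds 1 and 2 share one core; compound 3 carries a different core, and the difference between the two cores is not broken down here. Within the shared core of compounds 1 and 2 there is one change, (pyrrolidin-1-yl in place of piperidin-1-yl on an aromatic carbon), and it gives a number 10 percentage points lower from compound 2 to compound 1 (within the scatter). Compound 3 gives the highest number of the three, but its gap to compound 2 is within the scatter, and only its gap to compound 1 is beyond it, so no ordering between compound 3 and compound 2 is claimed.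

Compound 4 `c1cc(N2CCCC2)nc(Nc2ccc(Oc3ncnc4ccsc34)cc2)n1` is the unmeasured partner of compound 3: it differs from it by pyrrolidin-1-yl in place of piperidin-1-yl on an aromatic carbon, the same change as that from compound 2 to compound 1, at a place described in the same words. The step is therefore expected to be of the same kind, a number 9.5 percentage points lower from compound 3 to compound 4 (within the scatter), resting on compound 2 and compound 1 with a number 10 percentage points lower from compound 2 to compound 1 (within the scatter). For compound 4 in this assay the estimate is 52%, between 38% and 66%.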

Compound 4, a percentage reported as inhibition, at one concentration (the size of the read-out at that concentration, not a potency): 22.2%
The estimate for compound 4 lay 29.8 percentage points above the measured number; the whole stated range lies above it.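

On the core of compound 3, pyrrolidin-1-yl in place of piperidin-1-yl gives a number 39.3 percentage points lower from compound 3 to compound 4 (beyond the scatter) in this assay, so the size of this step cannot be carried from the shared core of compound 1 and compound 2 to the core of compound 3. Set side by side, the two steps differ: the same change on two cores in this assay, a number 10 percentage points lower (within the scatter) from compound 2 to compound 1 and a number 39.3 percentage points lower (beyond the scatter) from compound 3 to compound 4, 29.3 percentage points apart, beyond the scatter of two such steps This does not show why the two cores respond differently, nor how the step would behave on any further core, as each core offers a single pair read at one concentration.

The compounds shown leave open whether a different ring amine at this place, such as morpholine or piperazine, or an open-chain amine such as dimethylamino, would follow the pyrrolidin-1-yl or the piperidin-1-yl compounds on either core. They also leave open whether the gap seen in this assay would hold across a full concentration range.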